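The source may hold more compounds than are shown below. What is called first, only, known or untested is meant among the compounds shown, and "the series" means these compounds.

Measured in a functional assay on A549 cells (Homo sapiens) for cytotoxicity, read by WST assay, with a stated time of 48 h; a higher number here means a weaker inhibitor, a lower number a stronger inhibitor:
- Compound 1 `COc1ccc2c(C(=O)/C(C#N)=C/c3c[nH]c4cc(F)ccc34)c[nH]c2c1`: 800 nM
- Compound 2 `COc1ccc2c(C(=O)/C(C#N)=C/c3cn(Cc4ccc(Cl)cc4)c4ccccc34)c[nH]c2c1`: > 50000 nM
- Compound 3 `COc1ccc2c(C(=O)/C(C#N)=C/c3c[nH]c4ccc(OC)cc34)c[nH]c2c1`: 5500 nM

Compound 2 gives > 50000 nM, which is a limit of the assay and not a number. That leaves two true numbers for comparison. Of these, compound 3 at 5500 nM holds the higher one, marking it as the weaker inhibitor of the pair, and the gap down to compound 1 at 800 nM lies beyond the scatter.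

The next compound to be tested in this assay is compound 4 `COc1ccc2c(C(=O)/C(C#N)=C/c3c[nH]c4ccccc34)c[nH]c2c1`. It departs from compound 3 by a single change: hydrogen in place of methoxy on an aromatic carbon. In short, hydrogen stands in place of methoxy on an aromatic carbon.

Among the compounds with values here, no measured pair isolates this change, so any forecast is loose. The expectation leans on compound 1, which has no methoxy at that place and gives 800 nM. An expected step of a 2.8-fold lower number from compound 3 to compound 4 (0.44 log units; beyond the scatter) is therefore estimated to run toward a lower number, moderate in size and probably just beyond the scatter. For compound 4 the estimated value is 2000 nM, with an expected range from 500 nM to 8000 nM.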

Compound 4, half-maximal inhibitory concentration: 7500 nM
For compound 4 the middle estimate is 3.8-fold (0.57 log units) below the measured one, within the range that was stated.
By their numbers in this assay, from the lowest: compound 1; then compounds 3 and 4 (each within the scatter of the next). At a limit, above all of these: compound 2.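

In this assay, hydrogen in place of methoxy on this aromatic carbon gives a 1.4-fold higher number from compound 3 to compound 4 (0.13 log units; within the scatter), so this change leaves the number within the scatter and the methoxy at this place shows no effect of its own. With compound 4 as the reference, hydrogen in place of fluoro on an aromatic carbon gives a 9.4-fold higher number from compound 1 to compound 4 (0.97 log units; beyond the scatter), so the lower number of compound 1 is tied to its fluoro, a contrast that the methoxy of compound 3 does not share. Hydrogen in place of 4-chlorobenzyl on an aromatic nitrogen gives an at least 6.6-fold lower number from compound 2 to compound 4 (0.82 log units; beyond the scatter), a step read against a value of compound 2 that is a limit of the assay and not a number: the limit of > 50000 nM in this assay, at which 1 of the 4 values shown sits.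

From the compounds shown here alone, how fluoro would read on the aromatic carbon that bears the methoxy in compound 3 stays open, as does whether a chloro or an amine at that place would depart from compound 4. Also open, going by these compounds, is whether a methyl on the aromatic nitrogen would keep the number of compound 4 or move it toward the limit of compound 2.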